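The source may report more compounds than this note shows. Statements on the series, on what has been measured and on what is new or still open speak of the compounds shown alone.

Measured so far, both in a functional assay on Right cardiac atrium for agonist activity at histamine H2 receptor (Cavia porcellus), with a stated time of 30 min, in the presence of a further agent that is not named here; on this read-out lower numbers stand for smaller maximal responses and higher numbers for larger maximal responses: compound 1 `COc1ccc(C(C)NC(=O)/N=C(\N)NCCCc2sc(N)nc2C)cc1`, 0.91; compound 2 `Cc1nc(N)sc1CCCN/C(N)=N/C(=O)NC(C)c1cccs1`, 0.88.

Compound 2 stands beside compound 1: the step a number 0.030 lower from compound 1 to compound 2 (within the scatter) lies within the scatter, so the two cannot be told apart on these numbers. Compound 3 `Cc1nc(N)sc1CCCN/C(N)=N/C(=O)NC(C)c1cccc(F)c1` differs from compound 2 by 3-fluorophenyl in place of thiophen-2-yl on a saturated chain carbon bound to an amide-type nitrogen and a saturated chain carbon. Going by the values given here, the one measured step that bears on this, a number 0.030 lower from compound 1 to compound 2 (within the scatter), also exchanged the aromatic group on the same saturated chain carbon and stayed within the scatter. A further exchange there is therefore expected to give no step beyond the scatter, the estimated step being a number 0.010 higher from compound 2 to compound 3 (within the scatter). Compound 3 is estimated at 0.89, between 0.78 and 0.98.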

Compound 3, intrinsic activity: the largest response reached, as a fraction of the reference agonist's: 0.85
Beside the measured number, compound 3's estimate is 0.040 above it, within the range that was stated.
By their numbers in this assay, from the lowest: compounds 3, 2 and 1 (each within the scatter of the next).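

At the saturated chain carbon bound to an amide-type nitrogen and a saturated chain carbon, 3-fluorophenyl also holds the response in this assay: the steps are a number 0.030 lower from compound 2 to compound 3 (within the scatter) and a number 0.060 lower from compound 1 to compound 3 (within the scatter). Three aromatic groups, 3-fluorophenyl, thiophen-2-yl and 4-methoxyphenyl, therefore cannot be told apart at this place. No measurement shown accounts for this.

Still open, on these data alone, is whether a non-aromatic group at this place, such as cyclohexyl, would give a step beyond the scatter. The same holds for an aromatic ring carrying an amine or a carboxylic acid.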